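A few compounds are considered here, and "the series" means these few. Any claim that something is new, unique, unknown or untested is made for them only; others in the source may bear on it.

Series notes. For the measured compounds named here, in an ADME assay for permeability, using PAMPA, with a stated time of 30 min, at pH 7.4 (a higher number here means that the compound crosses the layer faster, a lower number that the compound crosses the layer more slowly), compound 3 `COc1ccc(Oc2ccc3c(NCCCNCc4cc(F)ccc4OC)ccnc3c2)cc1` gives 317 10^-6 cm/s, the highest of the three numbers measured so far: compound 1 `COc1ccc(F)cc1CNCCCNc1ccnc2cc(C3CCCCC3)ccc12` gives 23 10^-6 cm/s and compound 2 `c1ccc(CCc2ccc3c(NCCCNCc4ccco4)ccnc3c2)cc1` gives 23 10^-6 cm/s, each sitting below compound 3 by a margin beyond the scatter. Going by the values given here, the only single-point step measured so far, a 14-fold higher number from compound 1 to compound 3 (1.14 log units; beyond the scatter), is large. Compound 4 `COc1cccc(Oc2ccc3c(NCCCNCc4cc(F)ccc4OC)ccnc3c2)c1` keeps every atom of compound 3 and differs only in 3-methoxyphenyl in place of 4-methoxyphenyl on an oxygen on an aromatic ring. Among the compounds with values here, no measured step shifts a methoxy group around its ring; the step from compound 1 to compound 3 swapped one whole group for another and so does not bear directly on this change. Within the data shown here, with no comparable step to go on, the expected step is a 1.1-fold lower number from compound 3 to compound 4 (0.05 log units; within the scatter), which is expected to stay within the scatter. Compound 4 is therefore estimated at 280 10^-6 cm/s in this assay, with a range from 120 10^-6 cm/s to 600 10^-6 cm/s.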

Compound 4, apparent permeability: 317 10^-6 cm/s
For compound 4 the middle estimate is 1.1-fold (0.05 log units) below the measured one; the range from low to high includes it.
By their numbers in this assay, from the lowest: compounds 1 and 2 (each within the scatter of the next); then compounds 3 and 4 (each within the scatter of the next).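

In this assay, 3-methoxyphenyl in place of 4-methoxyphenyl on an oxygen on an aromatic ring reads as no change at the digits printed from compound 3 to compound 4 (within the scatter), so this relocation of the methoxy group, with every atom kept, does not separate the two compounds at this position. The large step away from cyclohexyl also holds for the second arrangement, with a 14-fold higher number from compound 1 to compound 4 (1.14 log units; beyond the scatter), so that step is not tied to 4-methoxyphenoxy alone. Nothing available bears on why the two arrangements read alike.

The compounds shown leave open whether a plain phenoxy group, or an amine or a carboxylic acid in place of the methoxy group, would keep the number at this level. They also leave open whether 2-methoxyphenoxy would fall in with 3-methoxyphenoxy and 4-methoxyphenoxy.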